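The source may report more compounds than this note shows. Statements on the series, on what has been measured and on what is new or still open speak of the compounds shown alone.

Compound 1: `Cc1cn([C@@H]2O[C@H](CO[Si](C)(C)C(C)(C)C)[C@@]3(OS(=O)(=O)C=C3NCCC(N)=O)[C@H]2O[Si](C)(C)C(C)(C)C)c(=O)n(C)c1=O` — 14800 nM
Compound 2: `CCOC(=O)CNC(=O)NC1=CS(=O)(=O)O[C@@]12[C@@H](CO[Si](C)(C)C(C)(C)C)O[C@@H](n1cc(C)c(=O)n(C)c1=O)[C@@H]2O[Si](C)(C)C(C)(C)C` — 13000 nM

Among the compounds with values here, in a functional assay on HEL cells (Homo sapiens) (a higher number here means that more compound is tolerated, a lower number that less compound is tolerated), compound 2 and compound 1 stand within the scatter of each other; the single measured step between them, a 1.1-fold lower number from compound 1 to compound 2 (0.06 log units; within the scatter), changes nothing that can be told apart from repeat measurements. Compound 3, `Cc1cn([C@@H]2O[C@H](CO[Si](C)(C)C(C)(C)C)[C@@]3(OS(=O)(=O)C=C3NCC(=O)C(N)=O)[C@H]2O[Si](C)(C)C(C)(C)C)c(=O)n(C)c1=O`, differs from compound 2 in one place: (carbamoylcarbonyl)methyl in place of ((ethoxycarbonyl)methyl)carbamoyl on an amine nitrogen. Within the data shown here, the only step that bears on this change is the one from compound 1 to compound 2, since it alters the same amine nitrogen, and that step was within the scatter. Among the measured compounds shown here, no measured step shows a substituent on this nitrogen shifting this assay beyond the scatter, so for compound 3 the expected step is a 1.1-fold higher number from compound 2 to compound 3 (0.03 log units; within the scatter). The estimate for compound 3 in this assay is therefore 14000 nM, with a range from 7000 nM to 28000 nM.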

Compound 3, half-maximal cytotoxic concentration: 14500 nM
Beside the measured number, compound 3's estimate is 1.0-fold (0.02 log units) below it, and the stated range covers the measured number.
By their numbers in this assay, from the lowest: compounds 2, 3 and 1 (each within the scatter of the next).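

In this assay, the step of a 1.1-fold higher number from compound 2 to compound 3 (0.05 log units; within the scatter) stays within the scatter, although the group that enters, (carbamoylcarbonyl)methyl, is smaller than ((ethoxycarbonyl)methyl)carbamoyl and the amine nitrogen no longer carries a carbamoyl. The narrower change, carbamoylcarbonyl in place of carbamoylmethyl on a saturated chain carbon bound to an amine nitrogen, gives a 1.0-fold lower number from compound 1 to compound 3 (0.01 log units; within the scatter) and also stays within the scatter, so adding a carbonyl to that chain makes no difference that can be told apart. All three groups on this nitrogen now lie within the scatter of one another, and nothing on record bears on this result.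

The compounds shown leave open whether a carboxylic acid, a basic amine or a much longer chain on this nitrogen would move the number beyond the scatter. They also leave open whether changes elsewhere on the shared core would do so.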